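The source may report more compounds than this note shows. Statements on the series, on what has been measured and on what is new or still open speak of the compounds shown alone.

Measured compounds:
Compound 1 `NCc1ccc(C(=O)Nc2ccncc2F)cc1-c1cccc(C(=O)OCC2CC2)c1` gives 2.7 nM in an assay on isolated protein for inhibition of Rho-associated protein kinase 2 (Homo sapiens), read by radiometric assay; on this read-out lower numbers stand for stronger inhibition and higher numbers for weaker inhibition.
Compound 2 `CC(C)OCCOC(=O)c1cccc(-c2cc(C(=O)Nc3ccncc3F)ccc2CN)c1` gives 37 nM in this assay.
Compound 3 `NCc1ccc(C(=O)Nc2ccncc2F)cc1-c1cccc(C(=O)OCC2CCCCO2)c1` gives 12 nM in this assay.

Compound 3 stands second highest among the three numbers; its nearest neighbour is compound 2, which lies a 3.1-fold lower number from compound 2 to compound 3 (0.49 log units; beyond the scatter) away, and its furthest is compound 1, reached by a 4.4-fold higher number from compound 1 to compound 3 (0.65 log units; beyond the scatter). Compound 4 `CCCOC(=O)c1cccc(-c2cc(C(=O)Nc3ccncc3F)ccc2CN)c1` has not yet been measured in this assay. It differs from compound 3 in one place: ethyl in place of oxan-2-yl on a saturated chain carbon bound to an oxygen next to a carbonyl group.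

Going by the values given here, two measured steps bear on this change, since both alter the same saturated chain carbon bound to the ester oxygen. Replacing cyclopropyl by oxan-2-yl gave a 4.4-fold higher number from compound 1 to compound 3 (0.65 log units; beyond the scatter), and replacing isopropoxymethyl by oxan-2-yl gave a 3.1-fold lower number from compound 2 to compound 3 (0.49 log units; beyond the scatter). The step to compound 4 removes the ring and its acceptor altogether, leaving a plain ethyl, which in this small set looks more like compound 1 than like compound 2. Compound 4 is therefore expected to show a modest decrease in this assay, about a 2.4-fold lower number from compound 3 to compound 4 (0.38 log units; beyond the scatter), with a value estimated near 5 nM and a likely range from 2 nM to 14 nM.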

Compound 4, half-maximal inhibitory concentration: 5.1 nM
Compound 4: the middle estimate sits 1.0-fold (0.01 log units) below what was measured; low and high end bracket the measured number.
By their numbers in this assay, from the lowest: compounds 1 and 4 (each within the scatter of the next); then compound 3; then compound 2.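

In this assay, ethyl in place of oxan-2-yl gives a 2.4-fold lower number from compound 3 to compound 4 (0.37 log units; beyond the scatter), while ethyl in place of cyclopropyl gives a 1.9-fold higher number from compound 1 to compound 4 (0.28 log units; within the scatter), so a ring on this saturated chain carbon is not needed to reach the lower numbers of this set. Methyl in place of isopropoxy gives a 7.3-fold lower number from compound 2 to compound 4 (0.86 log units; beyond the scatter), the largest of the new steps. Among the four compounds, the two esters whose side group carries an ether oxygen, compound 2 and compound 3, have the higher numbers, and compound 1 and compound 4, whose side groups have none, have the lower numbers, with no compound going against this.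

The compounds shown leave open how a longer chain such as butyl, or an amine or a carboxylic acid at the end of the chain, would read. No evidence is available on what lies behind this ranking.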